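A Methyl Added to the Isopropyl Group of Compound 1

This account rests on a few compounds, and the source may have more. Where it says the series, first, only, none or still open, it means among the compounds named here.

Compound 1, with structure `CC(=O)OC[C@H]1O[C@@H](n2cc(-c3cn(Cc4ccc(C(C)C)cc4)nn3)c(=O)[nH]c2=O)C[C@@H]1OC(C)=O`, is one of three compounds tested in a functional assay on NUGC-3 cells (Homo sapiens) for cytotoxicity, read by sulforhodamine B assay, tested at 10 uM; on this read-out lower numbers stand for less inhibition and higher numbers for more inhibition at the one concentration tested (going by the name of the read-out). Compound 1 gives 95.4%, the largest of the three numbers. Compound 2, `CC(C)(C)c1ccc(-c2cc(-c3cn([C@H]4C[C@H](O)[C@@H](CO)O4)c(=O)[nH]c3=O)on2)cc1`, gives 88% in this assay, a number within the usual scatter of that of compound 1. Compound 3, `CC(=O)OC[C@H]1O[C@@H](n2cc(-c3cc(-c4ccc(C(C)C)cc4)no3)c(=O)[nH]c2=O)C[C@@H]1OC(C)=O`, gives 56.4%, a number beyond the scatter below compound 1.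

Compound 4, `CC(=O)OC[C@H]1O[C@@H](n2cc(-c3cn(Cc4ccc(C(C)(C)C)cc4)nn3)c(=O)[nH]c2=O)C[C@@H]1OC(C)=O`, differs from compound 1 by methyl in place of hydrogen on a saturated chain carbon bound to an aromatic carbon and two saturated chain carbons. Among the compounds with values here, no measured pair shows such a change, so its size is unknown. A step from compound 1 to compound 4 of a number 3.4 percentage points lower from compound 1 to compound 4 (within the scatter) is expected, staying within the scatter. Compound 4 is expected to give 92%, between 78% and 99%, partly because compound 2 with its 4-(tert-butyl)phenyl gives 88%.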

Compound 4, a percentage reported as inhibition, at one concentration (the size of the read-out at that concentration, not a potency): 94.2%
The estimate for compound 4 lay 2.2 percentage points below the measured number; the range from low to high includes it.
By their numbers in this assay, from the lowest: compound 3; then compounds 2, 4 and 1 (each within the scatter of the next).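

Isopropyl to tert-butyl on the benzyl group now has a measured step: this assay shows a number 1.2 percentage points lower from compound 1 to compound 4 (within the scatter), so this position accepts the added methyl without a change beyond the scatter. Nothing available explains this result. A reading at one concentration is not a potency, so any difference in potency between these two compounds would remain hidden. As far as these compounds go, it remains open how the number would respond if an amine or a carboxylic acid replaced the tert-butyl group.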